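From compound 3 to compound 4: one rearranged group

A few compounds are considered here, and "the series" means these few. Any claim that something is new, unique, unknown or untested is made for them only; others in the source may bear on it.

Measured so far in an ADME assay on MDCK cells (Canis lupus familiaris) for cytotoxicity, with a stated time of 48 h; on this read-out lower numbers stand for higher toxicity in this test and higher numbers for lower toxicity in this test:
Compound 1 `C=C(C(=O)OC)[C@@H]1CC[C@H](C)[C@H]2C(=C(C)C(=O)[C@H]2NC(=O)CNC(=O)c2ccccc2)C1` gives 488 uM
Compound 2 `C=C(C(=O)OC)[C@@H]1CC[C@H](C)[C@H]2C(=C(C)C(=O)[C@H]2NS(=O)(=O)c2ccc(C)cc2)C1` gives 61.1 uM
Compound 3 `C=C(C(=O)NCc1ccc(B(O)O)cc1)[C@@H]1CC[C@H](C)[C@@H]2CC(=O)C(C)=C2C1` gives 262 uM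

Compound 3 (262 uM) cannot be told apart from compound 1 (488 uM) within the usual scatter, while compound 2 (61.1 uM) gives a lower number, beyond that scatter.

Compound 4 `C=C(C(=O)NCc1cccc(B(O)O)c1)[C@@H]1CC[C@H](C)[C@@H]2CC(=O)C(C)=C2C1` has the same atoms as compound 3, joined differently (a group of 9 heavy atoms (6 carbon, 1 boron, 2 oxygen; one six-membered aromatic ring of carbon only) in place of a group of 9 heavy atoms (6 carbon, 1 boron, 2 oxygen; one six-membered aromatic ring of carbon only), on a saturated chain carbon bound to an amide-type nitrogen). Within the data shown here, no measured pair shows a change of this kind, so the expectation rests on compound 3 (262 uM) alone. The step expected in this assay is a 1.0-fold lower number from compound 3 to compound 4 (0.02 log units; within the scatter) and so no shift beyond the scatter. Compound 4 is estimated at 250 uM (range 110 uM to 550 uM).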

Compound 4, half-maximal toxic concentration: 253 uM
Compound 4: the middle estimate sits 1.0-fold (0.01 log units) below what was measured, and the stated range covers the measured number.
By their numbers in this assay, from the lowest: compound 2; then compounds 4, 3 and 1 (each within the scatter of the next).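

In this assay, among these compounds, the rearranged group gives a 1.0-fold lower number from compound 3 to compound 4 (0.02 log units; within the scatter), the first comparison here of two compounds that differ in one place. On a saturated chain carbon bound to an amide-type nitrogen, joining the same atoms differently therefore leaves compound 3 and compound 4 impossible to tell apart. Nothing available explains this result. Still open, as far as these compounds go, is whether the number would hold with an amine or a carboxylic acid on the aromatic ring in place of the boron and its two oxygens. From the compounds shown here alone, a longer chain between the amide-type nitrogen and that ring is equally open.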